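Swapping the aryl on the pyridone nitrogen: compound 2 to compound 3

The source may hold more compounds than are shown below. What is called first, only, known or untested is meant among the compounds shown, and "the series" means these compounds.

Measured compounds:
compound 1, `Cn1ccc2c(Oc3ccc(NC(=O)c4cc5cccnc5n(-c5ccc(C(F)(F)F)cc5Cl)c4=O)cc3)ccnc21`, 6050 nM
compound 2, `COc1ccc(-n2c(=O)c(C(=O)Nc3ccc(Oc4ccnc5c4ccn5C)c(F)c3)cc3cccnc32)cc1`, 1290 nM

In a functional assay on HT-29 cells (Homo sapiens) for antiproliferative activity, read by MTT assay, with a stated time of 72 h (on this read-out higher numbers stand for weaker inhibition and lower numbers for stronger inhibition), compound 2 gives 1290 nM, the lowest of the two numbers seen so far. Compound 1 gives 6050 nM in this assay, a higher number that lies beyond the scatter of the two readings. The unmeasured compound 3, `Cn1ccc2c(Oc3ccc(NC(=O)c4cc5cccnc5n(-c5ccc(C(F)(F)F)cc5Cl)c4=O)cc3F)ccnc21`, differs from compound 2 by 2-chloro-4-(trifluoromethyl)phenyl in place of 4-methoxyphenyl on an aromatic nitrogen. Compound 1 also carries the 2-chloro-4-(trifluoromethyl)phenyl group, and its number in this assay is the weaker of the two, so the expectation is that the step in this assay from compound 2 to compound 3 goes toward a higher number, larger than the scatter. The expected step is a 3.1-fold higher number from compound 2 to compound 3 (0.49 log units; beyond the scatter). Compound 3 is estimated at 4000 nM, with a range from 1300 nM to 12000 nM.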

Compound 3, half-maximal inhibitory concentration: 5830 nM
For compound 3 the middle estimate is 1.5-fold (0.16 log units) below the measured one, within the range that was stated.
By their numbers in this assay, from the lowest: compound 2; then compounds 3 and 1 (each within the scatter of the next).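

In this assay, among the compounds shown here, 2-chloro-4-(trifluoromethyl)phenyl in place of 4-methoxyphenyl on the aromatic nitrogen gives a 4.5-fold higher number from compound 2 to compound 3 (0.66 log units; beyond the scatter), the first single-change reading at this position, and it shows that the choice of aryl there matters in this read-out. Fluoro in place of hydrogen on an aromatic carbon gives a 1.0-fold lower number from compound 1 to compound 3 (0.02 log units; within the scatter), so with 2-chloro-4-(trifluoromethyl)phenyl on the nitrogen, this fluoro leaves no difference beyond the scatter. Nothing at hand explains why the aryl change moves the number.

From the compounds shown here alone, the two substituents of the entering aryl are not separated, so it remains open whether the chloro or the trifluoromethyl goes with the higher number. Also open, going by these compounds, are how a phenyl bearing an amine or a carboxylic acid would read at this nitrogen, and whether the fluoro step holds with 4-methoxyphenyl there.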